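A few compounds are considered here, and "the series" means these few. Any claim that something is new, unique, unknown or untested is made for them only; others in the source may bear on it.

In a functional assay on Jurkat cells (Homo sapiens) for inhibition (a lower number here means a stronger inhibitor, a higher number a weaker inhibitor), compound 1 `Cc1nnsc1C(=O)Nc1ccc(-n2nc(C(F)(F)F)cc2C)cc1` gives 18 nM, and compound 2 `Cc1nnsc1C(=O)Nc1ccc(-n2nc(C(F)(F)F)cc2Cl)cc1` gives 15 nM, so compound 2 stands level with compound 1 within the scatter. Compound 3 `Cc1nnsc1C(=O)Nc1ccc(-n2nc(C(F)(F)F)cc2Br)cc1` differs from compound 2 at one place: bromo in place of chloro on an aromatic carbon. For the measured compounds named here, the one measured step that bears on this change is a 1.2-fold lower number from compound 1 to compound 2 (0.08 log units; within the scatter), a swap at the same place that stayed within the scatter. No step beyond the scatter is therefore expected in this assay, and the expected step is no change at the digits printed from compound 2 to compound 3 (within the scatter). Compound 3 is estimated at 15 nM, with an expected range of 7 nM to 32 nM.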

Compound 3, half-maximal inhibitory concentration: 5.9 nM
Estimate against measurement, compound 3: 2.5-fold (0.41 log units) above; the whole stated range lies above it.
By their numbers in this assay, from the lowest: compound 3; then compounds 2 and 1 (each within the scatter of the next).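

In this assay this position proves sensitive to the choice of group: bromo in place of chloro gives a 2.5-fold lower number from compound 2 to compound 3 (0.41 log units; beyond the scatter), whereas the earlier swap of methyl for chloro stayed within the scatter. Bromo in place of methyl gives a 3.1-fold lower number from compound 1 to compound 3 (0.48 log units; beyond the scatter), so of the three groups only bromo stands apart. Nothing at hand explains why bromo separates from chloro here. The compounds shown leave open whether iodo at this place would go further than bromo, and how a methoxy group or an amine would fare there.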